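A few compounds are considered here, and "the series" means these few. Any claim that something is new, unique, unknown or untested is made for them only; others in the source may bear on it.

Compound 1 `Cc1ccc(S(=O)(=O)[C@@]2(c3ccc(C(F)(C(F)(F)F)C(F)(F)F)cc3)CCN(C(=O)[C@H]3CC[C@H](C(=O)O)CC3)C2)cc1` with 0.013
Compound 2 `CCc1ccc(S(=O)(=O)[C@@]2(c3ccc(C(F)(C(F)(F)F)C(F)(F)F)cc3)CCN(C(=O)[C@H]3CC[C@H](C(=O)O)CC3)C2)cc1` with "not determined" (no result reported)

Going by the values given here, in an ADME assay on a cell-free system (plasma, Homo sapiens) for protein binding (on this read-out lower numbers stand for a smaller free fraction and higher numbers for a larger free fraction), compound 1 gives 0.013 as the only number. Compound 2 has no standing on this scale, since compound 2 is reported as "not determined" (no result reported) and no number came back. Compound 3 `Cc1cc(S(=O)(=O)[C@@]2(c3ccc(C(F)(C(F)(F)F)C(F)(F)F)cc3)CCN(C(=O)[C@H]3CC[C@H](C(=O)O)CC3)C2)ccc1F` carries 4-fluoro-3-methylphenyl in place of 4-ethylphenyl on a sulfonyl sulfur. Among the compounds with values here, no measured step exists to guide the exchange, so no shift beyond the scatter is expected in this assay and no direction can be given. For compound 3 the estimated value is 0.012 with an expected range from 0.005 to 0.028 on this read-out.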

Compound 3, unbound fraction: 0.017
Beside the measured number, compound 3's estimate is 1.4-fold (0.15 log units) below it; measured number inside the range.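

Going by these compounds alone, at the sulfonyl sulfur, 4-fluoro-3-methylphenyl in place of 4-methylphenyl gives, in this assay, a 1.3-fold higher number from compound 1 to compound 3 (0.12 log units; within the scatter), the first step that can be read at this position. This one exchange therefore leaves the two compounds indistinguishable on this read-out, while steps involving compound 2 cannot be read. Nothing available explains the result.

The compounds shown leave open whether any aryl group on the sulfonyl sulfur can move the number beyond the scatter. An aryl group carrying an amine or a methoxy group would test this.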